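Shortening the fluorinated chain on the carbamate of compound 1

The source may hold more compounds than are shown below. What is called first, only, known or untested is meant among the compounds shown, and "the series" means these compounds.

Measured compounds:
compound 1 `CCCc1ccc(S(=O)(=O)NC(=O)OCCC(F)(F)C(F)(F)F)c(-c2ccc(Cn3c(C(C)(C)C)nc4ccccc43)cc2)c1` — 6 nM
compound 2 `CCCCOC(=O)NS(=O)(=O)c1ccc(CCC)cc1-c1ccc(Cn2c(C3CCCCC3)nc3ccccc32)cc1` — 130 nM
compound 3 `CCCCOC(=O)NS(=O)(=O)c1ccc(CCC)cc1-c1ccc(Cn2c(-c3nccs3)nc3ccccc32)cc1` — 5.1 nM

In an assay on membranes from HEK293 cells for displacement of a labelled ligand from Type-2 angiotensin II receptor (Homo sapiens), read by radioligand binding (a higher number here means a weaker inhibitor, a lower number a stronger inhibitor), compound 1 gives 6 nM. Compound 3 gives 5.1 nM, a number within the usual scatter of compound 1, so the two cannot be ordered. Among the measured compounds shown here, compound 2, with 130 nM, stands well apart, and the only measured step shows it: a 25-fold lower number from compound 2 to compound 3 (1.41 log units; beyond the scatter). That step, however, concerns the group on the aromatic carbon of the shared core and not the carbamate chain.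

Compound 4 `CCCc1ccc(S(=O)(=O)NC(=O)OCCCC(F)(F)F)c(-c2ccc(Cn3c(C(C)(C)C)nc4ccccc43)cc2)c1` differs from compound 1 only at that chain: 2,2,2-trifluoroethyl in place of 1,1,2,2,2-pentafluoroethyl on a saturated chain carbon, two bonds along the chain from an oxygen next to a carbonyl group. No measured pair isolates this change, so nothing among the numbers shown speaks for a large step in either direction. The account therefore expects compound 4 to stay close to compound 1, with the step of a 1.3-fold higher number from compound 1 to compound 4 (0.12 log units; within the scatter) judged to lie within the scatter. The estimate for compound 4 in this assay is 8 nM, with a range from 3 nM to 20 nM.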

Compound 4, inhibition constant: 4.5 nM
Estimate against measurement, compound 4: 1.8-fold (0.25 log units) above, and the stated range covers the measured number.
By their numbers in this assay, from the lowest: compounds 4, 3 and 1 (each within the scatter of the next); then compound 2.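

Among the compounds shown here, compound 4 gives the only reading at this position, on a saturated chain carbon, two bonds along the chain from an oxygen next to a carbonyl group: in this assay the change appears as a 1.3-fold lower number from compound 1 to compound 4 (0.12 log units; within the scatter) and so the two compounds cannot be ordered. For the compounds shown here, on the core of compound 1, then, the end of the chain can pass from 1,1,2,2,2-pentafluoroethyl to 2,2,2-trifluoroethyl with no step that can be told from the scatter. Nothing measured here accounts for this result.

As far as these compounds go, it remains open whether a chain without fluorine, such as butyl on the core of compound 1, a longer fluorinated chain or a carboxylic acid at this position would read the same. Also open, from the compounds shown here alone, is whether this change would read the same with cyclohexyl or 1,3-thiazol-2-yl on the aromatic carbon of the shared core.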